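This account rests on a few compounds, and the source may have more. Where it says the series, first, only, none or still open, it means among the compounds named here.

Measured in a functional assay on PC-12 cells (Rattus norvegicus) for cytotoxicity, read by MTT assay, with a stated time of 24 h; a higher number here means that more compound is needed for the effect, a lower number that less compound is needed:
- compound 1 `COc1cccc(N2CCN(CC#CCOC(=O)c3sc4ncnc(N5CCCCC5)c4c3C)CC2)c1`: 40.4 ug/mL
- compound 2 `Cc1c(C(=O)OCC#CCN2CCN(c3cc(C4CC4)ccc3C#N)CC2)sc2ncnc(N3CCCCC3)c12`: 16.2 ug/mL
- compound 3 `Cc1ccc(-c2nnc(-c3sc4ncnc(N5CCCCC5)c4c3C)o2)cc1`: 28.2 ug/mL

Compound 3 lies within the scatter of both other compounds, so its number cannot be ranked against either of them. Only the gap between the other two is resolved, as a 2.5-fold lower number from compound 1 to compound 2 (0.40 log units; beyond the scatter).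

The next compound is compound 4 `Cc1c(-c2nnc(-c3ccc([N+](=O)[O-])cc3)o2)sc2ncnc(N3CCCCC3)c12`. It carries nitro in place of methyl on an aromatic carbon, para to a large group, which turns 4-methylphenyl into 4-nitrophenyl: nitro in place of methyl on an aromatic carbon.

Going by the values given here, no measured step tests this change. Among the compounds with values here, the one step available, a 2.5-fold lower number from compound 1 to compound 2 (0.40 log units; beyond the scatter), is modest and comes from 2-cyano-5-cyclopropylphenyl replacing 3-methoxyphenyl on an amine nitrogen in a ring. That is a different substituent at a different place, so it shows only the scale of movement seen so far in this assay. With no direct evidence for either direction, no shift beyond the scatter is expected, and the starting point remains compound 3 at 28.2 ug/mL.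

The expected move is a 1.1-fold lower number from compound 3 to compound 4 (0.05 log units; within the scatter).

For compound 4 the estimated value is 25 ug/mL, with an expected range of 10 ug/mL to 60 ug/mL.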

Compound 4, half-maximal effective concentration: 11.9 ug/mL
Estimate against measurement, compound 4: 2.1-fold (0.32 log units) above; measured number inside the range.
By their numbers in this assay, from the lowest: compounds 4, 2, 3 and 1 (each within the scatter of the next, the first and the last beyond it).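

In this assay, a 2.4-fold lower number from compound 3 to compound 4 (0.37 log units; beyond the scatter), so the group on this aromatic carbon, para to a large group, can move the number beyond the usual scatter: with nitro in place of methyl, less compound is needed for the effect. Going by these compounds alone, until now, the only resolved step was a 2.5-fold lower number from compound 1 to compound 2 (0.40 log units; beyond the scatter), made at the other end of the series on an aryl group carried by an amine nitrogen in a ring; this new step is also modest, and shows that the 4-methylphenyl end of the series responds to substitution as well. Nothing available gives a measured property of either group that would account for the step, so it stands as an observation on one pair only.

From the compounds shown here alone, whether the lower number is particular to nitro remains open, as one pair cannot show how an amine, a carboxylic acid or a chlorine atom on the same aromatic carbon would compare with 4-methylphenyl or 4-nitrophenyl. Going by these compounds, it is equally open whether a longer chain in place of methyl would leave the number within the scatter of compound 3 or move it, and in which direction.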